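Replacing tert-butoxycarbonyl on the chain of compound 3

A few compounds are considered here, and "the series" means these few. Any claim that something is new, unique, unknown or untested is made for them only; others in the source may bear on it.

In a physicochemical assay for solubility, read by HPLC, at pH 7.4 (on this read-out higher numbers stand for higher solubility and lower numbers for lower solubility), compound 3 (`Cc1[nH]c2ccccc2c(=O)c1/C=C/C(=O)OC(C)(C)C`) gives > 20000 nM as a limit of the assay and not a number. Compound 1 (`CCCCCCC/C=C/c1c(C)[nH]c2ccccc2c1=O`) gives < 2000 nM as a limit. Compound 2 (`CCCCCC/C=C\Cc1c(C)[nH]c2ccccc2c1=O`) gives < 2000 nM as a limit as well. Compound 3 therefore stands at the limit of > 20000 nM in this assay, at which 1 of the 3 values shown sits, and has no exact number.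

The change 4-hydroxyphenyl in place of tert-butoxycarbonyl on a double-bonded chain carbon bound to a double-bonded chain carbon leads to compound 4 (`Cc1[nH]c2ccccc2c(=O)c1/C=C/c1ccc(O)cc1`), with 4-hydroxyphenyl in place of tert-butoxycarbonyl on a double-bonded chain carbon bound to a double-bonded chain carbon. Going by the values given here, the only measured step at this place, an at least 10-fold higher number from compound 1 to compound 3 (1.00 log units; beyond the scatter) with heptyl leaving and tert-butoxycarbonyl entering, points to a lower number once that group leaves compound 3. Among the compounds with values here, no measured compound carries 4-hydroxyphenyl, and the size of the new step remains uncertain. The expected step in this assay is an at least 4.0-fold lower number from compound 3 to compound 4 (0.60 log units; beyond the scatter) and it is expected to lie beyond the scatter. For compound 4 the estimated solubility is 5000 nM with an expected range from 1500 nM to 20000 nM in this assay for now.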

Compound 4, solubility: > 20000 nM
Compound 4 was reported as a limit (the forecaster's own chance of this, stated with the estimate: 45%); middle value at least 4.0-fold (0.60 log units) from the limit.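

In this assay compound 4 gives > 20000 nM as a limit of the assay and not a number. With 4-hydroxyphenyl in place of heptyl on a double-bonded chain carbon bound to a double-bonded chain carbon, the series shows an at least 10-fold higher number from compound 1 to compound 4 (1.00 log units; beyond the scatter) and so the high read-out at this place is no longer tied to tert-butoxycarbonyl alone: a group with no ring and a group with a six-membered aromatic ring both reach the upper limit. The step from compound 3 to compound 4 cannot be read, as both values are limits.

Which of compound 3 and compound 4 is the more soluble stays open. Also open, from the compounds shown here alone, is how far the read-out would move at this place with a carboxylic acid, an amine or a chain shorter than heptyl.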